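Adding a methyl group to compound 3

A few compounds are considered here, and "the series" means these few. Any claim that something is new, unique, unknown or untested is made for them only; others in the source may bear on it.

In a functional assay on the whole organism (Hindlimb, strain albino) with Mus musculus as the target, in the maximal electroshock model, with a stated time of 0.5 h (a lower number here means that less compound is needed, a higher number that more compound is needed for the effect), compound 3 `O=C(/C=C/c1ccccc1)Nc1nc2ccccc2s1` gives 646 umol/kg. Compound 2 `O=C(/C=C/c1ccccc1)Nc1nc2ccc([N+](=O)[O-])cc2s1` gives 485 umol/kg, within the scatter of compound 3. Compound 1 `Cc1ccc2nc(NC(=O)/C=C/c3ccc(O)cc3)sc2c1` gives 271 umol/kg, a lower number than compound 3 and beyond the scatter.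

Compound 4 `Cc1ccc2nc(NC(=O)/C=C/c3ccccc3)sc2c1` follows from compound 3 by methyl in place of hydrogen on an aromatic carbon. Among the compounds with values here, the one measured single-place change, a 1.3-fold higher number from compound 2 to compound 3 (0.12 log units; within the scatter), is at a ring carbon of the shared core and stays small. Compound 1 carries methyl together with a hydroxyl group, so its value cannot isolate the methyl. A slightly lower number, within the scatter, is expected: a 1.4-fold lower number from compound 3 to compound 4 (0.14 log units; within the scatter). For compound 4 the estimated value is 470 umol/kg, with an expected range from 240 umol/kg to 900 umol/kg.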

Compound 4, dose for half-maximal effect: 380 umol/kg
Compound 4: middle estimate off by 1.2-fold (0.09 log units), on the high side, and the stated range covers the measured number.
By their numbers in this assay, from the lowest: compounds 1, 4, 2 and 3 (each within the scatter of the next, the first and the last beyond it).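

Methyl in place of hydrogen on this aromatic carbon can now be read alone in this assay and gives a 1.7-fold lower number from compound 3 to compound 4 (0.23 log units; within the scatter), with no separation of the two compounds. Methyl in place of nitro on the same carbon gives a 1.3-fold lower number from compound 2 to compound 4 (0.11 log units; within the scatter) and so leaves hydrogen, nitro and methyl here unresolved. Hydrogen in place of hydroxy on an aromatic carbon gives a 1.4-fold higher number from compound 1 to compound 4 (0.15 log units; within the scatter), so neither single change alone reaches beyond the scatter.

No measurement on hand explains these steps. Open, as far as these compounds go, is whether an amine, a carboxylic acid or a longer chain on this carbon would shift the number beyond the scatter.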